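This account rests on a few compounds, and the source may have more. Where it says the series, first, only, none or still open, it means among the compounds named here.

In an ADME assay on HepG2 2.2.15 cells (Homo sapiens) for cytotoxicity, read by CCK-8 assay, with a stated time of 8 days (a higher number here means that more compound is tolerated, a lower number that less compound is tolerated), three compounds have a reading so far. Compound 1 `CCOc1ccc(-n2cc(C(=O)c3ccc(OC)cc3O)ccc2=O)cc1` reads > 100000 nM as a limit of the assay and not a number. Compound 2 `COc1ccc(O)c(C(=O)Nc2c[nH]c(=O)c(-c3cccc(C)c3)c2)c1` gives 30100 nM and compound 3 `CCOc1ccc(-c2cc(NC(=O)c3cc(OC)ccc3O)c[nH]c2=O)cc1` gives 57700 nM and these two readings lie within the scatter of each other.

Compound 4 `CCOc1ccc(-c2cc(NC(=O)c3ccc(C)cc3O)c[nH]c2=O)cc1` differs from compound 3 through 2-hydroxy-4-methylphenyl in place of 2-hydroxy-5-methoxyphenyl on a carbonyl carbon and so carries 2-hydroxy-4-methylphenyl in place of 2-hydroxy-5-methoxyphenyl on a carbonyl carbon. Among the compounds with values here, no measured step touches this place. Within the data shown here, the one step available is a 1.9-fold higher number from compound 2 to compound 3 (0.28 log units; within the scatter) and it concerns a different group, so it is only a loose guide. It gives no sign of a large move, and no shift beyond the scatter is expected here. The expected change is a 1.3-fold lower number from compound 3 to compound 4 (0.11 log units; within the scatter) and carries no weight as a real difference. The reading could also end at the limit of > 100000 nM in this assay, at which 1 of the 3 values shown sits, rather than as a number. The estimated value for compound 4 is 45000 nM with an expected range from 18000 nM to 100000 nM in this measurement.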

Compound 4, half-maximal cytotoxic concentration: > 100000 nM
Compound 4 was reported as a limit; the forecaster's own chance of this, stated with the estimate: 15%; middle value at least 2.2-fold (0.34 log units) from the limit.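

Within the data shown here, compound 4 gives the first reading for a change at this place, the group on a carbonyl carbon bonded to an amide-type nitrogen: in this assay, 2-hydroxy-4-methylphenyl in place of 2-hydroxy-5-methoxyphenyl gives an at least 1.7-fold higher number from compound 3 to compound 4 (0.23 log units; that floor lies within the scatter). The reading of compound 4 is a limit of the assay and not a number, so this step is only a floor, and that floor alone does not separate the two compounds. The swap therefore shows no sign of less compound being tolerated, and the top of the range now holds a second compound: the limit of > 100000 nM in this assay, at which 2 of the 4 values shown sit.

The compounds shown do not tell whether the methoxy group leaving or the methyl group entering matters more. Also open, on these data alone, is how this aryl group would read carrying an amine or a carboxylic acid instead of the methyl group.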